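Changing the Anilide Group: Expected Cytotoxicity of Compound 4

The source may report more compounds than this note shows. Statements on the series, on what has been measured and on what is new or still open speak of the compounds shown alone.

Compound 1 `COc1ccc2c(=O)c(/C=C/C(=O)Nc3cccc(C)c3)coc2c1`: 554000 nM
Compound 2 `COc1ccc2c(=O)c(/C=C/C(=O)Nc3ccc(F)cc3)coc2c1`: 743000 nM
Compound 3 `COc1ccc2c(=O)c(/C=C/C(=O)Nc3ccc(C)cc3)coc2c1`: 979000 nM

These three compounds share one core and differ only in the aromatic group attached to the amide-type nitrogen. In an ADME assay on HepG2 2.2.15 cells (Homo sapiens) for cytotoxicity, read by MTT assay, with stated times of 48 h and 9 days (a lower number here means that less compound is tolerated, a higher number that more compound is tolerated), compound 1 gives the smallest of the three numbers, but the step to compound 2 a 1.3-fold higher number from compound 1 to compound 2 (0.13 log units; within the scatter) and the step to compound 3 a 1.8-fold higher number from compound 1 to compound 3 (0.25 log units; within the scatter) both stay within the scatter, so the three compounds cannot be told apart on this read-out. The step from compound 2 to compound 3 a 1.3-fold higher number from compound 2 to compound 3 (0.12 log units; within the scatter) is likewise within the scatter.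

Compound 4 `CCOc1ccc(NC(=O)/C=C/c2coc3cc(OC)ccc3c2=O)cc1` continues this series. Compared with compound 1 the change is 4-ethoxyphenyl in place of 3-methylphenyl on an amide-type nitrogen. The two measured steps that start from compound 1 also replaced 3-methylphenyl on the amide-type nitrogen with a different aromatic group, and neither moved the number beyond the scatter. Nothing measured here points to a larger effect for the 4-ethoxyphenyl group, so no step beyond the scatter is expected in this assay, in either direction.

Compound 4 is therefore expected to give about 700000 nM, with a likely range from 350000 nM to 1400000 nM, which means an expected step of a 1.3-fold higher number from compound 1 to compound 4 (0.10 log units; within the scatter).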

Compound 4, half-maximal cytotoxic concentration: 460000 nM
Estimate against measurement, compound 4: 1.5-fold (0.18 log units) above, within the range that was stated.
By their numbers in this assay, from the lowest: compounds 4, 1, 2 and 3 (each within the scatter of the next, the first and the last beyond it).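

Replacing 3-methylphenyl with 4-ethoxyphenyl on the amide-type nitrogen adds an oxygen and a larger group, yet in this assay the result is still only a 1.2-fold lower number from compound 1 to compound 4 (0.08 log units; within the scatter), and replacing fluoro with ethoxy on an aromatic carbon gives a 1.6-fold lower number from compound 2 to compound 4 (0.21 log units; within the scatter). The new information comes from replacing methyl with ethoxy on an aromatic carbon, which gives a 2.1-fold lower number from compound 3 to compound 4 (0.33 log units; beyond the scatter), the first modest separation in this small set and one found only between these two compounds, while each neighbouring pair in the order by number stays within the scatter. No measurement here offers an explanation for that separation.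

As far as these compounds go, whether a butoxy chain in place of the ethoxy group would widen the separation or leave it unchanged remains open. From the compounds shown here alone, it is also open whether an amine or a carboxylic acid at that place on the aromatic ring would move the number further than any of the groups compared here.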